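Amide nitrogen substituent series, working notes toward compound 3

A few compounds are considered here, and "the series" means these few. Any claim that something is new, unique, unknown or untested is made for them only; others in the source may bear on it.

Of the compounds shown here, two of the shared core have been measured in a functional assay on the whole organism for inhibition, with Rattus norvegicus as the target, read by cytopathic effect and paw edema, at a dose of 100 mg/kg by the oral route; on this read-out higher numbers stand for more inhibition at the one dose given (going by the name of the read-out) and lower numbers for less inhibition. Compound 1 `CNC(=O)c1c(O)c2cccnc2n(-c2ccccc2)c1=O`, with methyl on the amide nitrogen, gives 21%. Compound 2 `Cc1ccccc1NC(=O)c1c(O)c2cccnc2n(-c2ccccc2)c1=O`, with 2-methylphenyl in that position, gives 9.8%. Compound 2 thus stands lowest of the two numbers in hand; the step of a number 11.2 percentage points lower from compound 1 to compound 2 (beyond the scatter) lies beyond the scatter, so the drop is read as real though modest.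

Compound 3 `O=C(NCc1ccncc1)c1c(O)c2cccnc2n(-c2ccccc2)c1=O` is the next member, and its change from compound 2 is (pyridin-4-yl)methyl in place of 2-methylphenyl on an amide-type nitrogen.

Going by the values given here, only one measured step touches this position, a number 11.2 percentage points lower from compound 1 to compound 2 (beyond the scatter), and it compares methyl against 2-methylphenyl; neither end of it is (pyridin-4-yl)methyl, so no measured step bears directly on the change. All that can be drawn from it is that this position moves the read-out by a modest amount. The step of a number 8.2 percentage points higher from compound 2 to compound 3 (within the scatter) is therefore expected to be modest and, if anything, upward, with a return toward the level of compound 1 as the likelier case and a result within the scatter of compound 2 also possible. Compound 3 is estimated at 18%, in a range from 4% to 36%.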

Compound 3, a percentage reported as inhibition, in the whole organism at one dose (the size of the read-out at that dose, not a potency): 15.4%
Estimate against measurement, compound 3: 2.6 percentage points above; measured number inside the range.
By their numbers in this assay, from the lowest: compounds 2, 3 and 1 (each within the scatter of the next, the first and the last beyond it).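

In this assay the (pyridin-4-yl)methyl group on the amide-type nitrogen gives a number that cannot be separated from either earlier compound (a number 5.6 percentage points higher from compound 2 to compound 3 (within the scatter); a number 5.6 percentage points lower from compound 1 to compound 3 (within the scatter)). Going by these compounds alone, the position thus takes an aromatic ring with one hetero atom, held on a saturated chain carbon, with no step beyond the scatter from methyl or from 2-methylphenyl, and the only step beyond it remains the one between the two earlier groups (a number 11.2 percentage points lower from compound 1 to compound 2 (beyond the scatter)). Nothing measured here bears on why the three compounds fall as they do.

The compounds shown leave open whether the ring nitrogen or the saturated chain carbon of (pyridin-4-yl)methyl counts for anything, a question that a benzyl group on the same nitrogen would separate. Also open, on these data alone, is whether any group at this position lifts the read-out clear of all three compounds, for instance a longer chain ending in an amine or a carboxylic acid, and the single oral dose gives no potency for any of them.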